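Replacing the pyridyl group: compound 3 to compound 4

A few compounds are considered here, and "the series" means these few. Any claim that something is new, unique, unknown or untested is made for them only; others in the source may bear on it.

Measured compounds:
compound 1 `O=C1CC(c2nc(-c3ccccc3)no2)CN1c1ccccc1`: 350 nM
compound 2 `Cc1cccc(-c2noc(C3CC(=O)N(c4ccc(Cl)cc4)C3)n2)c1`: 170 nM
compound 3 `Cc1cccc(-c2noc(C3CC(=O)N(c4ccc(F)cc4)C3)n2)n1`: > 10000 nM

In an in vitro functional assay on HEK293-A cells for positive allosteric modulation of metabotropic glutamate receptor 5 (Homo sapiens), read by FLIPR and calcium flux (on this read-out higher numbers stand for an effect only at larger amounts of compound and lower numbers for an effect already at smaller amounts), compound 1 gives 350 nM and compound 2 gives 170 nM; these two values lie within the usual scatter of each other. For compound 3 this assay reports only a limit, > 10000 nM, not a number; this is the limit of > 10000 nM in this assay, at which 1 of the 3 values shown sits. Compound 3 therefore stands apart from compound 1 and compound 2, which both carry a six-membered aromatic ring of carbon only at the same place and both give a measured value.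

Compound 4 `COc1cccc(-c2noc(C3CC(=O)N(c4ccc(F)cc4)C3)n2)c1` differs from compound 3 in one place: 3-methoxyphenyl in place of 6-methylpyridin-2-yl on an aromatic carbon. The entering group is again a six-membered aromatic ring of carbon only, of the kind seen in compound 1 and compound 2. On that basis compound 4 is expected to show a measured value in this assay rather than a limit, and the expected step of an at least 25-fold lower number from compound 3 to compound 4 (1.39 log units; beyond the scatter) is toward an effect at smaller amounts, well beyond the scatter. The estimate for compound 4 is 400 nM, with a range from 100 nM to 3000 nM; compound 3 is the only comparator for this exact change, so the range is wide.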

Compound 4, half-maximal effective concentration: 1100 nM
Compound 4: the middle estimate sits 2.8-fold (0.44 log units) below what was measured, and the stated range covers the measured number.
By their numbers in this assay, from the lowest: compound 2; then compound 1; then compound 4. At a limit, above all of these: compound 3.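

Exchanging 6-methylpyridin-2-yl for 3-methoxyphenyl on the aromatic carbon between two ring nitrogen atoms gives an at least 9.0-fold lower number from compound 3 to compound 4 (0.95 log units; beyond the scatter) in this assay, the only direct step shown at this position. Compound 1 and compound 2 differ from compound 3 in more than one place, whereas this pair keeps the rest of the structure fixed, showing that a change at this one place is enough to separate a limit from a measured value. Compound 3 carries a limit and not a number, so the step has a floor and no upper end: the limit of > 10000 nM in this assay, at which 1 of the 4 values shown sits.

The step replaces the ring nitrogen and exchanges methyl for methoxy at once, so the pair cannot show which of the two changes carries the difference, and a comparison of a pyridyl ring carrying methoxy with a phenyl ring carrying methyl on the same core would be needed to separate them. On these data alone, how far this position extends beyond these groups also stays open, for example with an amine or a carboxylic acid in place of the methoxy on the phenyl ring.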